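Trimethoxybenzophenone cinnamamides: next step in the series

The source may hold more compounds than are shown below. What is called first, only, known or untested is meant among the compounds shown, and "the series" means these compounds.

Measured so far, in a functional assay on HeLa cells (Homo sapiens) for cytotoxicity, read by MTT assay, with a stated time of 72 h; on this read-out higher numbers stand for weaker inhibition and lower numbers for stronger inhibition:
Compound 1, `COc1ccc(/C=C/C(=O)Nc2cc(C(=O)c3cc(OC)c(OC)c(OC)c3)cc(OC)c2OC)cc1N`, gives 15800 nM.
Compound 2, `C#CCOc1cccc(/C=C/C(=O)Nc2cc(C(=O)c3cc(OC)c(OC)c(OC)c3)cc(OC)c2OC)c1`, gives 7300 nM.

Compound 2 holds the lower of the two numbers in this assay. Going by the values given here, the single step known, a 2.2-fold lower number from compound 1 to compound 2 (0.34 log units; beyond the scatter), is what separates the two, and it lies beyond the scatter though it is modest in size.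

Compound 3, `COc1cc(C(=O)c2cc(OC)c(OC)c(OC)c2)cc(NC(=O)/C=C/c2ccc(C(F)(F)F)cc2)c1OC`, is not yet measured. It differs from compound 2 by 4-(trifluoromethyl)phenyl in place of 3-(propargyloxy)phenyl on a double-bonded chain carbon bound to a double-bonded chain carbon. Among the compounds with values here, no measured step repeats this exchange. Within the data shown here, the only step available, a 2.2-fold lower number from compound 1 to compound 2 (0.34 log units; beyond the scatter), alters the same ring in the same place, and it shows that a change of substituent on that ring shifts this assay by a modest amount rather than by a large one. Nothing in the data points to a direction for the present exchange, so the working expectation is a number close to that of compound 2, with a wide range on either side.

Compound 3 is therefore expected to give about 7500 nM in this assay, within 2500 nM to 22000 nM. That estimate corresponds to an expected step of a 1.0-fold higher number from compound 2 to compound 3 (0.01 log units; within the scatter), which is no change beyond the scatter.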

Compound 3, half-maximal inhibitory concentration: 3000 nM
For compound 3 the middle estimate is 2.5-fold (0.40 log units) above the measured one; the measured number falls inside the stated range.
By their numbers in this assay, from the lowest: compound 3; then compound 2; then compound 1.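

In this assay, going by these compounds alone, the exchange at the ring on the double-bonded chain carbon gives a 2.4-fold lower number from compound 2 to compound 3 (0.39 log units; beyond the scatter), a second modest step at this place and the first involving a group without a hydrogen-bond acceptor: 4-(trifluoromethyl)phenyl replaces 3-(propargyloxy)phenyl. Compound 3 now holds the lowest number of the three, with its steps to both others beyond the scatter, and the widest gap at this place is a 5.3-fold lower number from compound 1 to compound 3 (0.72 log units; beyond the scatter), still modest in size, so a hydrogen-bond acceptor on this ring is not required for the lowest number in the set. No measurement is available that accounts for the order of these three groups.

The exchange alters both the group and where it stands on the ring, so the compounds shown do not separate the contribution of the trifluoromethyl group from that of its location. Also open, as far as these compounds go, is how this assay responds to a plain phenyl ring without any substituent, or to a nitrile or a carboxylic acid in place of the trifluoromethyl group on the same ring.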